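Replacing benzylamino with 4-carbamoylpiperidin-1-yl: outlook for compound 3

The compounds below may be only part of what the source reports. "The series", "measured", "known", "first", "only" and "open" are said of these compounds alone.

Two compounds have numbers in an ADME assay on Jurkat cells (Homo sapiens) for inhibition, read by WST assay, with a stated time of 48 h, tested at 10 uM; a higher number here means more inhibition at the concentration tested (going by the name of the read-out), a lower number less inhibition. Compound 1 `N#Cc1c(-c2ccc(Cl)cc2)nc(SCc2ccccc2)nc1N1CCC(C(N)=O)CC1` carries a 4-carbamoylpiperidin-1-yl group, and in this assay compound 1 gives 19%. Compound 2 `COc1ccc(-c2nc(SCc3ccccc3)nc(NCc3ccccc3)c2C#N)cc1` carries benzylamino and a 4-methoxyphenyl group; in this assay compound 2 gives 5%, the lowest of the two numbers, with compound 1 as nearest neighbour standing higher by a gap beyond the scatter. Among the compounds with values here, no step between measured compounds that differ in one place is available, so the amine swap has no measured precedent.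

Compound 3 `COc1ccc(-c2nc(SCc3ccccc3)nc(N3CCC(C(N)=O)CC3)c2C#N)cc1` is not yet measured. It differs from compound 2 as follows: 4-carbamoylpiperidin-1-yl in place of benzylamino on an aromatic carbon. Compound 3 shares the 4-carbamoylpiperidin-1-yl group with compound 1 and the 4-methoxyphenyl group with compound 2, so its number is expected to lie between those two. The expected step is a number 7 percentage points higher from compound 2 to compound 3 (within the scatter), a modest rise at the edge of the scatter. The estimate for compound 3 in this assay is 12%, with a range from 0% to 25%.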

Compound 3, a percentage reported as inhibition, at one concentration (the size of the read-out at that concentration, not a potency): 12%
Compound 3: the middle estimate sits on the measured number at the digits printed, within the range that was stated.
By their numbers in this assay, from the lowest: compounds 2, 3 and 1 (each within the scatter of the next, the first and the last beyond it).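

In this assay, the position on the aromatic carbon next to the ring nitrogen, ortho to the cyano group, now has a one-place comparison: 4-carbamoylpiperidin-1-yl in place of benzylamino gives a number 7 percentage points higher from compound 2 to compound 3 (within the scatter) and so cannot be told apart from the usual variation between repeats. The aryl substituent also has a one-place comparison: methoxy in place of chloro gives a number 7 percentage points lower from compound 1 to compound 3 (within the scatter) and likewise stays unresolved, so neither single change is shown to shift the read-out. No measured data on these compounds bear on the cause of either step.

As far as these compounds go, whether a morpholine ring or a piperidine-4-carboxylic acid at this position would move the number beyond the scatter remains open. From the compounds shown here alone, the effect of changing the benzylsulfanyl group, shared by all three compounds, is also open.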